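This account rests on a few compounds, and the source may have more. Where it says the series, first, only, none or still open, it means among the compounds named here.

The measured compounds:

Compound 1, `COc1ccc(/C=C/[C@@](C)(/C=C/c2ccc(O)c(/C=C/C#N)c2)CCC=C(C)C)cc1`: in a functional assay on NALM-6 cells (Homo sapiens) for cytotoxicity, with a stated time of 72 h (a higher number here means that more compound is needed for the effect, a lower number that less compound is needed), compound 1 gives 16500 nM.
Compound 2, `CC(C)=CCC[C@@](C)(/C=C/c1ccccc1)/C=C/c1ccc(O)cc1`: compound 2 reaches only a limit of the assay, > 43400 nM.
Compound 3, `C=C[C@@](C)(/C=C/c1ccc(Nc2ccc(OC)cc2)cc1)CCC=C(C)C`: compound 3 likewise reaches only a limit, > 43400 nM.

Compound 3 therefore has no number of its own here, only (the limit of > 43400 nM in this assay, at which 2 of the 3 values shown sit); the one full number among the three belongs to compound 1, and no single-change step between any two of these compounds has been measured. The unmeasured compound 4, `C=C[C@@](C)(/C=C/c1ccc(Nc2ccc(Cl)cc2)cc1)CCC=C(C)C`, differs from compound 3 by chloro in place of methoxy on an aromatic carbon. Because compound 3 sits at the limit > 43400 nM, there is no measured step in this assay on which to lean for the size of this change, and nothing in the shown values ties a chloro or a methoxy to a particular shift. The expectation is that compound 4 stays roughly where compound 3 is, with an at least 1.0-fold lower number from compound 3 to compound 4 (0.03 log units; that floor lies within the scatter), a step that would not count beyond the scatter. Compound 4 is estimated at 40000 nM, in a range from 12000 nM to 130000 nM, and it is expected that the assay may once more report only a limit.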

Compound 4, half-maximal effective concentration: > 43400 nM
Compound 4 gave a limit, no number; the forecaster's own chance of this, stated with the estimate: 65%; at least 1.0-fold (0.03 log units) between middle value and limit.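

Compound 3 and compound 4 both end at a limit in this assay, not at a number, so no step can be read for chloro in place of methoxy: the limit of > 43400 nM in this assay, at which 3 of the 4 values shown sit. The compounds shown leave open whether this change shifts the result in this assay at all.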